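This account rests on a few compounds, and the source may have more. Where it says the series, first, only, none or still open, it means among the compounds named here.

Compound 1 `COc1nc2c(c(=O)n(C)c(=O)n2C)n1CC(=O)Nc1ccc(C(C)(C)C)cc1`: in an assay on isolated protein for inhibition of high affinity 3',5'-cyclic-AMP phosphodiesterase 7A (Homo sapiens), read by cAMP accumulation, with a stated time of 10 min (a lower number here means a stronger inhibitor, a higher number a weaker inhibitor), compound 1 gives > 200000 nM, a limit of the assay.
Compound 2 `CCOc1nc2c(c(=O)n(C)c(=O)n2C)n1CC(=O)Nc1ccc(Cl)cc1`: in this assay compound 2 gives > 200000 nM, again a limit.
Compound 3 `CCOc1nc2c(c(=O)n(C)c(=O)n2C)n1CC(=O)Nc1ccc(C(C)C)cc1`: in this assay compound 3 gives > 200000 nM, again a limit.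

Compound 3 stands at the limit of this assay, with no number of its own; the two further values shown are limits as well. Among the compounds with values here, the only measured step, a step that the two limits leave unreadable from compound 2 to compound 3, is unreadable since both its ends are limits. The whole of the evidence is the limit of > 200000 nM in this assay, at which 3 of the 3 values shown sit.

Compound 4 `CCOc1nc2c(c(=O)n(C)c(=O)n2C)n1CC(=O)Nc1ccc(C(C)(C)C)cc1` differs from compound 3 by methyl in place of hydrogen on a saturated chain carbon bound to an aromatic carbon and two saturated chain carbons. Compound 1, which already carries the tert-butyl group that enters here, gives > 200000 nM, a limit. Within the data shown here, no measured step in this assay can be read, so nothing among the measured compounds points to a change of readable size. Compound 4 is therefore expected to remain at the limit of this assay. The estimated step that the limit leaves unreadable from compound 3 to compound 4 is expected to be none beyond the scatter. Compound 4 is estimated at 400000 nM, within the range 150000 nM to 2000000 nM.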

Compound 4, half-maximal inhibitory concentration: > 200000 nM
Compound 4: only a limit was reported (the forecaster's own chance of this, stated with the estimate: 90%); the middle value lies beyond the limit too.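

No new step can be read: compound 4, like compound 1, compound 2 and compound 3, sits at a limit, so its steps from those compounds stay unreadable: the limit of > 200000 nM in this assay, at which 4 of the 4 values shown sit.

The compounds shown leave open what change to this series would give a readable value in this assay at all.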